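Adding one methoxy group to compound 2

A few compounds are considered here, and "the series" means these few. Any claim that something is new, unique, unknown or untested is made for them only; others in the source may bear on it.

In a functional assay on HT-1080 cells (Homo sapiens) for cytotoxicity, read by MTT assay, with a stated time of 72 h (a higher number here means a weaker inhibitor, a lower number a stronger inhibitor), the measured compounds give these values:
- Compound 1 `COc1ccccc1/C=C1\CCC/C(=C\c2cccc(OC)c2OC)C1=O` gives 14100 nM
- Compound 2 `COc1ccc(/C=C2\CCC/C(=C\c3cccc(OC)c3OC)C2=O)cc1` gives 16300 nM
- Compound 3 `COc1cccc(/C=C2\CCC/C(=C\c3ccc(O)cc3)C2=O)c1OC` gives > 20000 nM as a limit of the assay, not a number

Among the compounds with values here, compound 2 cannot be told apart from compound 1, the only other compound with a true number (a 1.2-fold higher number from compound 1 to compound 2 (0.06 log units; within the scatter)). That step shifts a methoxy group around one ring. Compound 4 `COc1ccc(/C=C2\CCC/C(=C\c3cccc(OC)c3OC)C2=O)c(OC)c1` keeps the core of compound 2 and has methoxy in place of hydrogen on an aromatic carbon, ortho to a large group and meta to a methoxy group (methoxy in place of hydrogen on an aromatic carbon). The other relevant step removes a methyl from an oxygen, and its floor lies within the scatter (an at least 1.2-fold higher number from compound 2 to compound 3 (0.08 log units; that floor lies within the scatter)). No step beyond the scatter is therefore expected in this assay in either direction. The estimated step is a 1.2-fold lower number from compound 2 to compound 4 (0.07 log units; within the scatter) on this reasoning. For compound 4 the estimated value is 14000 nM with 6000 nM to 20000 nM as the expected range.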

Compound 4, half-maximal inhibitory concentration: > 20000 nM
Compound 4: a limit, no number (the forecaster's own chance of this, stated with the estimate: 25%); at least 1.4-fold (0.15 log units) between middle value and limit.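

In this assay compound 4 gives > 20000 nM as a limit of the assay, not a number. Methoxy in place of hydrogen, ortho to a large group and meta to a methoxy group, thus yields only floors: an at least 1.2-fold higher number from compound 2 to compound 4 (0.08 log units; that floor lies within the scatter) and an at least 1.4-fold higher number from compound 1 to compound 4 (0.15 log units; that floor lies within the scatter) are the steps, and neither floor leaves the scatter. The true size of the change cannot be read because the readings stop at a ceiling: the limit of > 20000 nM in this assay, at which 2 of the 4 values shown sit.

An amine or a carboxylic acid at this place remains untested in the compounds shown. So does whether any group here gives a clearly lower number.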